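Notes on a chain-end change in the benzamide series

The compounds below may be only part of what the source reports. "The series", "measured", "known", "first", "only" and "open" are said of these compounds alone.

Going by the values given here, compound 2 `COc1cc(N)c(Cl)cc1C(=O)NC1CCN(CCCCCCCCO)CC1` is measured in an assay on HEK293 cells for displacement of a labelled ligand from 5-hydroxytryptamine receptor 4 (Homo sapiens), read by scintillation counting (a lower number here means a stronger inhibitor, a higher number a weaker inhibitor), at 79.4 nM, the higher of the two numbers so far; compound 1 `COc1cc(N)c(Cl)cc1C(=O)NC1CCN(CCCCCO)CC1` gives 63.1 nM in this assay, and the step of a 1.3-fold higher number from compound 1 to compound 2 (0.10 log units; within the scatter) stays within the scatter, so no order between compound 1 and compound 2 can be read from these two values.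

Compound 3 `COc1cc(N)c(Cl)cc1C(=O)NC1CCN(CCCCCN2C(=O)c3ccccc3C2=O)CC1` is not yet measured. Relative to compound 2 the change is a group of 11 heavy atoms (8 carbon, 1 nitrogen, 2 oxygen; one five-membered non-aromatic ring with 1 hetero atom, one six-membered aromatic ring of carbon only) in place of a group of 4 heavy atoms (3 carbon, 1 oxygen; no ring), on a saturated chain carbon, five bonds along the chain from an amine nitrogen in a ring. Among the compounds with values here, the only measured step, a 1.3-fold higher number from compound 1 to compound 2 (0.10 log units; within the scatter), alters the chain ending in hydroxy and keeps the hydroxy itself, so it does not probe an exchange of the hydroxy for a ring-bearing group. Within the data shown here, no measured pair bears directly on the step from compound 2 to compound 3. Among the measured compounds shown here, with that step within the scatter as the only guide, the expected outcome is a number near that of compound 2, with a wide margin in either direction. For compound 3 the estimate in this assay is 60 nM, with a range from 12 nM to 300 nM, which amounts to an expected step of a 1.3-fold lower number from compound 2 to compound 3 (0.12 log units; within the scatter).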

Compound 3, inhibition constant: 20 nM
Compound 3: the middle estimate sits 3.0-fold (0.48 log units) above what was measured; measured number inside the range.
By their numbers in this assay, from the lowest: compound 3; then compounds 1 and 2 (each within the scatter of the next).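

In this assay, going by these compounds alone, the chain end is the first place where a change moves the number beyond the scatter: the ring-bearing group that replaces the 3-hydroxypropyl gives a 4.0-fold lower number from compound 2 to compound 3 (0.60 log units; beyond the scatter), and the same comparison against the shorter hydroxy chain gives a 3.2-fold lower number from compound 1 to compound 3 (0.50 log units; beyond the scatter). Both steps are modest, yet they make compound 3 the strongest inhibitor of the three and show that a terminal hydroxy is not required at this place on a saturated chain carbon, five bonds along the chain from an amine nitrogen in a ring, and that this position accepts a group of two rings with a lower number as the result. Nothing available explains the step.

The ring-bearing group enters as a whole, so the contribution of its aromatic ring, its carbonyl groups and its ring nitrogen remains unseparated; a chain ending in a plain phenyl or in an amine would begin to divide them. A longer chain carrying the same group would show whether the lower number holds when that group sits farther from the amine nitrogen in a ring.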